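A few compounds are considered here, and "the series" means these few. Any claim that something is new, unique, unknown or untested is made for them only; others in the source may bear on it.

In a functional assay on PC-3 cells (Homo sapiens) for antiproliferative activity, read by sulforhodamine B assay, with a stated time of 48 h (a lower number here means a stronger inhibitor, a higher number a weaker inhibitor), compound 1 `O=C(CCCCCCN1C(=O)/C(=N\O)c2ccccc21)NO` gives 980 nM. Compound 2 `O=C(CCCCCCN1C(=O)/C(=N\O)c2cc(F)ccc21)NO`, carrying fluoro, gives 2730 nM, and compound 3 `O=C(CCCCCCN1C(=O)/C(=N\O)c2cc(Cl)ccc21)NO`, carrying chloro, gives 850 nM. Compound 3 thus shares the low end of these three numbers with compound 1. Fluoro for hydrogen gave a 2.8-fold higher number from compound 1 to compound 2 (0.44 log units; beyond the scatter), and chloro for fluoro gave a 3.2-fold lower number from compound 2 to compound 3 (0.51 log units; beyond the scatter). Compound 4 `O=C(CCCCCCN1C(=O)/C(=N\O)c2cc(Br)ccc21)NO` brings one further change: bromo in place of chloro on an aromatic carbon. Among the measured compounds shown here, no measured step involves bromo, so the closest guide is chloro for hydrogen, which gave a 1.2-fold lower number from compound 1 to compound 3 (0.06 log units; within the scatter). No step beyond the scatter is therefore expected in this assay, though the fluoro result shows that halogens can differ. The expected change is a 1.1-fold higher number from compound 3 to compound 4 (0.02 log units; within the scatter). The estimate for compound 4 is 900 nM, with an expected range of 400 nM to 2000 nM.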

Compound 4, half-maximal inhibitory concentration: 2210 nM
For compound 4 the middle estimate is 2.5-fold (0.39 log units) below the measured one; measured number outside the range, above it.
By their numbers in this assay, from the lowest: compounds 3 and 1 (each within the scatter of the next); then compounds 4 and 2 (each within the scatter of the next).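

In this assay, this position proves sensitive to the choice of halogen: bromo in place of chloro gives a 2.6-fold higher number from compound 3 to compound 4 (0.41 log units; beyond the scatter) and so does not repeat the chloro result. Bromo in place of hydrogen gives a 2.3-fold higher number from compound 1 to compound 4 (0.35 log units; beyond the scatter) in the same direction as fluoro, and bromo in place of fluoro gives a 1.2-fold lower number from compound 2 to compound 4 (0.09 log units; within the scatter) within the scatter, leaving chloro alone among these halogens level with hydrogen. Nothing available explains why chloro stands apart. Still open, on these data alone, is how a methoxy group or an amine would behave at this position, and whether a longer chain would change the halogen order.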